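Cinnamate Esters Tested in Mice: Aryl Variation

The compounds below may be only part of what the source reports. "The series", "measured", "known", "first", "only" and "open" are said of these compounds alone.

Measured so far:
Compound 1 `COc1cc(OC)c(OC)cc1/C=C/COC(=O)/C=C/c1ccc(OC)c(OC)c1OC` gives 25% in a functional assay on the whole organism (strain Kunming) with Mus musculus as the target, with a stated time of 0.5 h, at a dose of 300 mg/kg by the intraperitoneal route; on this read-out lower numbers stand for a stronger effect and higher numbers for a weaker effect at the one dose given.
Compound 2 `COc1cc(OC)c(OC)cc1/C=C/COC(=O)/C=C/c1c(OC)ccc(OC)c1OC` gives 50% in this assay.
Compound 3 `COc1cc(OC)c(OC)cc1/C=C/COC(=O)/C=C/c1cccc(Br)c1` gives 25% in this assay.

Compound 3 stands level with compound 1 at the digits reported, and together these two give the lowest numbers of the three. Its nearest neighbour by value is compound 1, with no change at the digits shown, which lies within the scatter. Its furthest neighbour is compound 2, whose number lies higher by an amount beyond the scatter.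

Compound 4 `COc1ccc(/C=C/C(=O)OC/C=C/c2cc(OC)c(OC)cc2OC)cc1` has not yet been measured in this assay. It differs from compound 3 in one place: 4-methoxyphenyl in place of 3-bromophenyl on a double-bonded chain carbon bound to a double-bonded chain carbon. For the measured compounds named here, no measured pair in this set isolates that change, so its size cannot be read from the data. Compounds 1 and 2, both carrying methoxy-bearing aryl groups at the same position of the chain, differ by a step beyond the scatter, which shows that changes in that aryl group can move the read-out either way.

Compound 4 is therefore expected to give 35%, with a range from 15% to 60%. That estimate implies an expected step of a number 10 percentage points higher from compound 3 to compound 4 (within the scatter), which is judged to lie within the scatter.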

Compound 4, a percentage reported as activity, at one dose (the size of the read-out at that dose, not a potency): 0%
For compound 4 the middle estimate is 35 percentage points above the measured one; the whole stated range lies above it.
By their numbers in this assay, from the lowest: compound 4; then compounds 1 and 3 (each within the scatter of the next); then compound 2.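

In this assay, 4-methoxyphenyl in place of 3-bromophenyl on a double-bonded chain carbon bound to a double-bonded chain carbon gives a number 25 percentage points lower from compound 3 to compound 4 (beyond the scatter). For the compounds shown here, this is the first step in the set that isolates a single change, and it shows that exchanging the aryl group at this place alone can shift the read-out beyond the scatter, here towards a stronger effect at the one dose given. The exchange alters both the substituent and its printed ring number, so the step belongs to the whole swap, and nothing shown explains why the number falls.

Going by these compounds, it remains open what a 4-bromophenyl or a 3-methoxyphenyl group would give at this place, and so whether the step follows the substituent or its location on the ring. Also open, on these data alone, are the effect of an aryl group carrying an amine or a carboxylic acid, and how compound 4 would compare with compound 3 at a lower dose, where a single-dose reading offers no guide.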